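Removing the Carboxy Group from a Glutamate Receptor Modulator

The source may report more compounds than this note shows. Statements on the series, on what has been measured and on what is new or still open speak of the compounds shown alone.

Of the compounds shown here, three built on one shared core have been measured in an assay for positive allosteric modulation of metabotropic glutamate receptor 2 (Rattus norvegicus); a higher number here means that more compound is needed for the effect, a lower number that less compound is needed. Compound 1, `Cc1c(OCCCCOc2ccc(Cl)c(C(=O)O)c2)ccc(C(=O)CC(C)(C)C)c1O`, gives 87 nM. Compound 2, `CNC(=O)c1cc(OCCCCOc2ccc(C(=O)CC(C)(C)C)c(O)c2C)ccc1F`, gives 164 nM. Compound 3, `COc1ccc(OCCCCOc2ccc(C(=O)CC(C)(C)C)c(O)c2C)cc1C(=O)O`, gives 13 nM, the lowest of the three numbers, and its gaps to both other compounds lie beyond the scatter. Among the compounds with values here, the only single-place step among them, a 6.7-fold lower number from compound 1 to compound 3 (0.83 log units; beyond the scatter), leads into compound 3.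

Compound 4, `COc1ccc(OCCCCOc2ccc(C(=O)CC(C)(C)C)c(O)c2C)cc1`, differs from compound 3 in one place: hydrogen in place of carboxy on an aromatic carbon. The group leaves from an aromatic carbon that is ortho to a methoxy group and meta to a large group. Within the data shown here, no measured step touches this position. The step from compound 1 to compound 3 alters a different substituent, and compound 2 differs from compound 3 in two places, so its number cannot be tied to the carboxy group alone. Still, compound 1 at 87 nM and compound 3 at 13 nM, both carrying a carboxy group, give the two lowest numbers, while compound 2, which lacks it, gives 164 nM. A rise in this assay is therefore expected, and the estimated step is a 12-fold higher number from compound 3 to compound 4 (1.06 log units; beyond the scatter). Compound 4 is estimated at 150 nM, with a range from 40 nM to 600 nM.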

Compound 4, half-maximal effective concentration: > 10000 nM
Compound 4 was reported as a limit; the forecaster's own chance of this, stated with the estimate: 10%; middle value at least 66-fold (1.82 log units) from the limit.
By their numbers in this assay, from the lowest: compound 3; then compounds 1 and 2 (each within the scatter of the next). At a limit, above all of these: compound 4.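

Compound 4 is reported only as a limit and not as a number: the limit of > 10000 nM in this assay, at which 1 of the 4 values shown sits. In this assay, within the data shown here, taking the carboxy group off this aromatic carbon, ortho to a methoxy group, gives an at least 760-fold higher number from compound 3 to compound 4 (2.88 log units; beyond the scatter) and so shows for the first time how much hangs on this one position, since the earlier step from compound 1 to compound 3 changed a different substituent and left the carboxy group in place. The change from the chloro-bearing compound gives an at least 110-fold higher number from compound 1 to compound 4 (2.06 log units; beyond the scatter), so both carboxy compounds lie far from compound 4, although this wider step alters the chloro position as well and cannot be tied to the carboxy group alone.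

Compound 2 goes against any simple rule that a carboxy group is required, as it has none and still gives 164 nM, but it differs from compound 3 in two places, so what it contributes here stays unclear. The compounds shown also leave open whether a methyl ester, a nitrile or a tetrazole on this same carbon would keep the low number of compound 3 or fall to the level of compound 4, and they give no reason for the loss.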